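This account rests on a few compounds, and the source may have more. Where it says the series, first, only, none or still open, it means among the compounds named here.

Compound 1 `COc1cc2c(Oc3ccc(NC(=O)N/N=C/c4ccc([N+](=O)[O-])cc4)cc3F)ccnc2cc1OCCCN1CCCC1`: 310 nM
Compound 2 `COc1cc2c(Oc3ccc(NC(=O)N/N=C/c4ccc(C(F)(F)F)cc4)cc3F)ccnc2cc1OCCCN1CCCC1`: 810 nM

Both were tested in a functional assay on HT-29 cells (Homo sapiens) for cytotoxicity, read by MTT assay, with a stated time of 72 h; on this read-out lower numbers stand for stronger inhibition and higher numbers for weaker inhibition. Going by the values given here, on these two numbers compound 1 stands lowest; the only other value is that of compound 2, and a 2.6-fold higher number from compound 1 to compound 2 (0.42 log units; beyond the scatter), with trifluoromethyl in place of nitro on an aromatic carbon.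

Compound 3 `COc1cc2c(Oc3ccc(NC(=O)N/N=C/c4ccc([N+](=O)[O-])cc4)cc3F)ccnc2cc1OCCCN1CCC(C)CC1` has not yet been measured. It differs from compound 1 by 4-methylpiperidin-1-yl in place of pyrrolidin-1-yl on a saturated chain carbon, three bonds along the chain from an oxygen on an aromatic ring. Among the compounds with values here, no measured step speaks to this change: the single step measured so far alters a group on an aromatic ring and leaves the ring at the end of the chain untouched, so it offers no guide to swapping that ring. With nothing to point either way, the expected step in this assay is none beyond the usual scatter, in either direction, and the nitro compound 1 is taken as the starting point. Compound 3 is therefore estimated at 350 nM, within 120 nM to 1000 nM. The step this estimate means is a 1.1-fold higher number from compound 1 to compound 3 (0.05 log units; within the scatter), expected to stay within the scatter.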

Compound 3, half-maximal inhibitory concentration: 230 nM
Compound 3: the middle estimate sits 1.5-fold (0.18 log units) above what was measured; low and high end bracket the measured number.
By their numbers in this assay, from the lowest: compounds 3 and 1 (each within the scatter of the next); then compound 2.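

Going by these compounds alone, the only earlier step changed a group on an aromatic ring, so this pair gives the first reading on the ring at the end of the chain. In this assay, 4-methylpiperidin-1-yl in place of pyrrolidin-1-yl gives a 1.3-fold lower number from compound 1 to compound 3 (0.13 log units; within the scatter), so the two compounds cannot be told apart on this read-out. With the nitro group in place, this position, on a saturated chain carbon, three bonds along the chain from an oxygen on an aromatic ring, therefore accepts either a five-membered ring or a six-membered ring carrying a methyl group without a change beyond the scatter, and no accompanying measurement offers an explanation for this result.

Going by these compounds, it remains open whether the same ring swap would also leave the number within the scatter in the trifluoromethyl series of compound 2, as this single pair speaks only for the nitro compounds. Also open, on these data alone, is how the chain end would respond to a morpholine ring, a piperazine ring, an open-chain dimethylamine or a carboxylic acid, or to a shorter or longer chain linking the amine to the oxygen.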